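The compounds below may be only part of what the source reports. "The series", "measured", "known", "first", "only" and "open" are said of these compounds alone.

Working notes on the series read in a functional assay on HCT-116 cells (Homo sapiens) for cytotoxicity, read by MTT assay, with a stated time of 48 h; on this read-out lower numbers stand for stronger inhibition and higher numbers for weaker inhibition. Compound 1 (`COc1cc(/C=C/c2ccc(OCCCC(=O)NO)cc2)cc(OC)c1`) gives 5200 nM, compound 2 (`COc1cc(/C=C/c2ccc(OCCCCCCCC(=O)NO)cc2)cc(OC)c1`) gives 12600 nM, and compound 3 (`COc1cc(/C=C/c2ccc(OCc3ccccc3C(=O)NO)cc2)cc(OC)c1`) gives 13900 nM. Compound 3 thus sits at the weak end of this small set, level with compound 2 within the scatter, a 1.1-fold higher number from compound 2 to compound 3 (0.04 log units; within the scatter), and apart from compound 1, a 2.7-fold higher number from compound 1 to compound 3 (0.43 log units; beyond the scatter).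

Compound 4 (`COc1cc(/C=C/c2ccc(OCc3cccc(C(=O)NO)c3)cc2)cc(OC)c1`) keeps the shared core and carries 3-(hydroxycarbamoyl)phenyl in place of 2-(hydroxycarbamoyl)phenyl on a saturated chain carbon bound to an oxygen on an aromatic ring.

Among the compounds with values here, no measured pair differs in this way alone, so the evidence is indirect. The nearest steps are those that replace a chain with 2-(hydroxycarbamoyl)phenyl, named above, and the chain change itself, a 2.4-fold higher number from compound 1 to compound 2 (0.38 log units; beyond the scatter). Even these larger replacements are modest or lie within the scatter, which argues against a large effect from a smaller change. The expected step is a 1.5-fold lower number from compound 3 to compound 4 (0.17 log units; within the scatter), with no shift beyond the scatter anticipated and only a slight lean toward the middle of the series. For compound 4 the estimated value is 9500 nM, with an expected range of 3800 nM to 22000 nM.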

Compound 4, half-maximal inhibitory concentration: 13700 nM
The estimate for compound 4 lay 1.4-fold (0.16 log units) below the measured number; low and high end bracket the measured number.
By their numbers in this assay, from the lowest: compound 1; then compounds 2, 4 and 3 (each within the scatter of the next).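

In this assay the exchange of 3-(hydroxycarbamoyl)phenyl for 2-(hydroxycarbamoyl)phenyl on a saturated chain carbon bound to an oxygen on an aromatic ring gives the first direct read between two ring-bearing groups at this place (a 1.0-fold lower number from compound 3 to compound 4 (0.01 log units; within the scatter)), and the two groups cannot be told apart on this read-out. Compound 4 also stands level with the 6-(hydroxycarbamoyl)hexyl group (a 1.1-fold higher number from compound 2 to compound 4 (0.04 log units; within the scatter)) and apart from the 2-(hydroxycarbamoyl)ethyl group (a 2.6-fold higher number from compound 1 to compound 4 (0.42 log units; beyond the scatter)), so compounds 2, 3 and 4 now form one cluster, with only compound 1 standing apart from it. No measurement at hand explains why the exchange of these two groups leaves the number level.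

The compounds shown leave open whether 4-(hydroxycarbamoyl)phenyl at the same place would also stay level with compound 3 and compound 4, or would instead come closer to compound 1. They also leave open whether a 4-(hydroxycarbamoyl)butyl group would fall with compound 1 or with the cluster, and whether a carboxylic acid in place of the hydroxycarbamoyl group would change the number at all.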